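The source may report more compounds than this note shows. Statements on the series, on what has been measured and on what is new or still open speak of the compounds shown alone.

Compounds measured so far:
- compound 1 `COc1cccc(CNCc2c(-c3nnc(SC(C)C)n3-c3ccccc3)n(C)c3ccc(F)cc23)c1`: 6.42
- compound 2 `COc1cccc(CNCc2c(-c3nnc(SC(C)C)n3-c3ccccc3)n(C)c3ccccc23)c1`: 6.27

In a physicochemical assay for lipophilicity (on this read-out lower numbers stand for lower lipophilicity and higher numbers for higher lipophilicity), compound 1 gives 6.42, the higher of the two numbers recorded; in this assay compound 2 gives 6.27. Going by the values given here, the only step between measured compounds is a number 0.15 log units lower from compound 1 to compound 2 (within the scatter), so these two compounds cannot be told apart on this read-out.

Compound 3 `CC(C)Sc1nnc(-c2c(CNC3CC3)c3cc(F)ccc3n2C)n1-c1ccccc1` has not yet been measured. It differs from compound 1 in one place: cyclopropyl in place of 3-methoxybenzyl on an amine nitrogen. Among the compounds with values here, none of the measured steps touches the amine nitrogen; the step from compound 1 to compound 2 concerns a different position and was within the scatter, so it offers no direct guide. The expectation therefore rests on the structural change alone: a group of nine heavy atoms with an aromatic ring leaves and a group of three heavy atoms enters, which is expected to lower the number in this assay well beyond the scatter.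

Compound 3 is expected to give about 5.2, within a range from 4.7 to 5.7, an estimated step of a number 1.22 log units lower from compound 1 to compound 3 (beyond the scatter).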

Compound 3, partition coefficient: 4.97
Beside the measured number, compound 3's estimate is 0.23 log units above it; measured number inside the range.
By their numbers in this assay, from the lowest: compound 3; then compounds 2 and 1 (each within the scatter of the next).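

Going by these compounds alone, the amine nitrogen is the first place where a change clearly moves the number: in this assay, the swap to cyclopropyl gives a number 1.45 log units lower from compound 1 to compound 3 (beyond the scatter) and stands well clear of the scatter. Within the data shown here, the only earlier step, a number 0.15 log units lower from compound 1 to compound 2 (within the scatter) on an aromatic carbon, could not separate its two compounds, so this change shows that the read-out can respond strongly. The swap changes several things at once, since 3-methoxybenzyl brings more heavy atoms, a six-membered aromatic ring and a hydrogen-bond acceptor, while cyclopropyl brings a three-membered non-aromatic ring and no acceptor, and nothing at hand explains the size of the step or assigns it to any one of these differences.

An unsubstituted benzyl group on the same nitrogen would show how much of the step goes with the methoxy group and how much with the aromatic ring, while a cyclohexyl group or a longer chain such as n-butyl would show how the number follows size without an aromatic ring. From the compounds shown here alone, it also remains open whether replacing fluoro with hydrogen would stay within the scatter when cyclopropyl sits on the amine nitrogen.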